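The compounds below may be only part of what the source reports. "The series", "measured", "known", "first", "only" and "open" are said of these compounds alone.

Measured compounds:
- compound 1, `Cc1nc(-c2ccc(Cl)cc2)sc1C(=O)CSc1nc(-c2ccccc2)c(C#N)c(=O)[nH]1`: 11.4%
- compound 2, `COc1ccc(-c2nc(SCC(=O)c3sc(-c4ccccc4)nc3C)[nH]c(=O)c2C#N)cc1`: 1.08%
- compound 3, `Cc1nc(-c2ccc(Cl)cc2)sc1C(=O)CSc1nc(-c2ccc(Cl)c(Cl)c2)c(C#N)c(=O)[nH]1`: 36.5%

In a functional assay on U-87MG ATCC cells for antiproliferative activity against U-87 MG (Homo sapiens), read by MTT assay, with a stated time of 48 h, tested at 100 uM (a higher number here means a weaker effect of the compound at the concentration tested, a lower number a stronger effect), compound 3 stands highest of the three numbers. Nearest to it is compound 1, whose value lies lower by a number 25.1 percentage points higher from compound 1 to compound 3 (beyond the scatter), a step beyond the scatter. Furthest is compound 2, lower still; no single-point step between compound 2 and compound 3 is recorded, so only the two values themselves can be compared.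

Compound 4, `Cc1nc(-c2ccc(Cl)cc2)sc1C(=O)CSc1nc(-c2cccc(Cl)c2)c(C#N)c(=O)[nH]1`, is not yet measured. It differs from compound 3 by hydrogen in place of chloro on an aromatic carbon. Read one bond further out, this is 3,4-dichlorophenyl to 3-chlorophenyl, which places compound 4 partway between the phenyl of compound 1 and the 3,4-dichlorophenyl of compound 3. Going by the values given here, the only step that bears on it is a number 25.1 percentage points higher from compound 1 to compound 3 (beyond the scatter), which added two chloro groups at once and raised the number by a modest amount. Among the compounds with values here, removing one of them is therefore expected to move part of the way back: a step downward in this assay of a number 12.5 percentage points lower from compound 3 to compound 4 (beyond the scatter), with considerable uncertainty since no single-chloro analogue has been measured. Compound 4 is expected to give about 24%, within 8% to 42%.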

Compound 4, a percentage reported as activity, at one concentration (the size of the read-out at that concentration, not a potency): 12.5%
Compound 4: the middle estimate sits 11.5 percentage points above what was measured; measured number inside the range.
By their numbers in this assay, from the lowest: compound 2; then compounds 1 and 4 (each within the scatter of the next); then compound 3.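

In this assay, taking off the chloro para to a large group, which turns 3,4-dichlorophenyl into 3-chlorophenyl, gives a number 24 percentage points lower from compound 3 to compound 4 (beyond the scatter). Set against the phenyl, the 3-chlorophenyl gives a number 1.1 percentage points higher from compound 1 to compound 4 (within the scatter), so the earlier step that added both chloro groups at once now comes apart: one chloro shows no readable change, and the higher number appears only with the 3,4-dichlorophenyl of compound 3. No measurement at hand offers a reason for this behaviour.

Open, on these data alone, is whether the chloro on this carbon needs the other chloro to raise the number, a question that a 4-chlorophenyl would address. Also open, as far as these compounds go, is whether a bromo, a fluoro or an amine on the same carbon would follow the chloro or the hydrogen.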